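One group exchanged between compound 3 and compound 4

The compounds below may be only part of what the source reports. "The series", "measured", "known", "first", "only" and "open" are said of these compounds alone.

Measured so far in a physicochemical assay for lipophilicity, at pH 7.4; on this read-out higher numbers stand for higher lipophilicity and lower numbers for lower lipophilicity:
compound 1 `Cc1cc(COc2cccc(F)c2F)nc(-c2ccccn2)n1`: 3.2
compound 2 `Cc1cc(COc2cc(F)cc(F)c2F)nc(-c2ccccn2)n1`: 3.4
compound 3 `Fc1ccc(OCc2cc(N3CC4(CCO4)C3)nc(-c3ccccn3)n2)c(F)c1F`: 3.3

In this assay compound 3, at 3.3, lies within the scatter of the other two numbers. Compound 4 `COC1(COc2cc(COc3ccc(F)c(F)c3F)nc(-c3ccccn3)n2)COC1` has not yet been measured. It differs from compound 3 in one place: a group of 8 heavy atoms (5 carbon, 3 oxygen; one four-membered non-aromatic ring with 1 hetero atom) in place of a group of 7 heavy atoms (5 carbon, 1 nitrogen, 1 oxygen; 2 four-membered non-aromatic rings with 1 hetero atom each), on an aromatic carbon, so that (3-methoxyoxetan-3-yl)methoxy now sits on that aromatic carbon. For the measured compounds named here, the only measured step, a number 0.20 log units higher from compound 1 to compound 2 (within the scatter), is fluoro in place of hydrogen on an aromatic carbon. That is a different change and gives no direct measure of this one. The closest guide is a loose one: compound 1 at 3.2 and compound 3 at 3.3 lie within the scatter of each other, although their structures differ in more than one place. No shift beyond the scatter is therefore expected in this assay, and the direction is uncertain. The expected step is a number 0.10 log units lower from compound 3 to compound 4 (within the scatter) in this estimate. For compound 4 the estimate is 3.2, with an expected range from 2.8 to 3.6.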

Compound 4, distribution coefficient: 3.5
Compound 4: the middle estimate sits 0.30 log units below what was measured; measured number inside the range.
By their numbers in this assay, from the lowest: compounds 1, 3, 2 and 4 (each within the scatter of the next).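

On this aromatic carbon of the shared core, (3-methoxyoxetan-3-yl)methoxy, with one four-membered ring and no nitrogen, takes the place of a group with two such rings and one nitrogen, and in this assay this gives a number 0.20 log units higher from compound 3 to compound 4 (within the scatter). For the compounds shown here, this is the first reading of any change at this position, and it shows that two groups of such different make-up can be exchanged here without a step beyond the scatter. No measurement is available that explains this result.

On these data alone, it remains open whether a group of another kind on this carbon, such as a carboxylic acid or a longer alkyl chain, would give a step beyond the scatter. It is also unknown whether this same exchange would give a similar step with a different arrangement of fluoro groups elsewhere in the molecule.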